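The compounds below may be only part of what the source reports. "The series", "measured", "known", "first", "only" and "open" are said of these compounds alone.

Compound 1 `NC1=NC2(CCOCC2)N(OCCCOc2ccc(Cl)cc2Cl)C(N)=N1`: 70 nM
Compound 2 `NC1=NC2(CCOCC2)N(OCCCOc2cccc(Br)c2)C(N)=N1`: 160 nM

Both values come from a functional assay on A549 cells (Homo sapiens) for antiproliferative activity, read by MTT assay, with a stated time of 72 h; on this read-out lower numbers stand for stronger inhibition and higher numbers for weaker inhibition. Of the two, compound 2 has the higher number, at 160 nM, which makes it the weaker of the pair. The next compound to be tested is compound 3 `Cc1ccc(OCCCON2C(N)=NC(N)=NC23CCOCC3)cc1`. It keeps the shared core and chain of compound 2 and changes only the aromatic end: 4-methylphenyl in place of 3-bromophenyl on an oxygen on a saturated carbon. In words, this is 4-methylphenyl in place of 3-bromophenyl on an oxygen on a saturated carbon.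

Going by the values given here, only one measured step bears on this change: a 2.3-fold higher number from compound 1 to compound 2 (0.36 log units; beyond the scatter). It was a modest step, made at the same place by 3-bromophenyl replacing 2,4-dichlorophenyl. Among the compounds with values here, no measured compound carries 4-methylphenyl, so this single pair gives a rough size and no firm direction. A step no larger than that one is therefore expected, possibly lost in the scatter, with only a slight lean towards a higher number. The expected change is a 1.3-fold higher number from compound 2 to compound 3 (0.10 log units; within the scatter). For compound 3 the estimated value is 200 nM, with an expected range from 70 nM to 600 nM.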

Compound 3, half-maximal inhibitory concentration: 1060 nM
Beside the measured number, compound 3's estimate is 5.3-fold (0.72 log units) below it, and the stated range ends below it.
By their numbers in this assay, from the lowest: compound 1; then compound 2; then compound 3.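

In this assay, going by these compounds alone, the aromatic end of the chain proves more sensitive than the one earlier step suggested: 4-methylphenyl in place of 3-bromophenyl gives a 6.6-fold higher number from compound 2 to compound 3 (0.82 log units; beyond the scatter), a larger step than a 2.3-fold higher number from compound 1 to compound 2 (0.36 log units; beyond the scatter) on the same shared core and chain. Within the data shown here, replacing 2,4-dichlorophenyl with 4-methylphenyl gives a 15-fold higher number from compound 1 to compound 3 (1.18 log units; beyond the scatter), so this single position alone spreads the series widely, and the two compounds with halogens on the ring, compound 1 and compound 2, both have lower numbers than compound 3, the one with a methyl group, although three compounds are a thin basis for any pattern and none of them goes against it. Nothing available explains the size of these steps.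

From the compounds shown here alone, the change from compound 2 to compound 3 alters both the substituent and its ring position, so it remains open whether the loss follows the methyl group or its position, a question that 3-methylphenyl or 4-bromophenyl at this end of the chain could separate. Also open, going by these compounds, is how this assay would respond to an amine or a carboxylic acid on the ring, or to a longer chain leading to it.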